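Swapping the aryl group on the shared core

A few compounds are considered here, and "the series" means these few. Any claim that something is new, unique, unknown or untested is made for them only; others in the source may bear on it.

The two measured compounds share one core and differ only in the group attached to the five-membered ring. Compound 1 `COc1ccc(-c2cc(COC(Cc3cn(C4CCN(Cc5ccc([N+](=O)[O-])cc5)CC4)nn3)c3ccc(Br)cc3)on2)cc1` carries a 4-methoxyphenyl there; in a functional assay on PC-3 cells (Homo sapiens) for cytotoxicity, with a stated time of 48 h (on this read-out lower numbers stand for stronger inhibition and higher numbers for weaker inhibition), compound 1 gives 3000 nM. Compound 2 `N#Cc1ccc(-c2cc(COC(Cc3cn(C4CCN(Cc5ccc([N+](=O)[O-])cc5)CC4)nn3)c3ccc(Br)cc3)on2)cc1` carries a 4-cyanophenyl; in this assay compound 2 gives 2000 nM. Going by the values given here, the step of a 1.5-fold lower number from compound 1 to compound 2 (0.18 log units; within the scatter) is the only measured step, and it stays within the scatter, so compound 2 has the lowest of the two numbers without being set apart from compound 1.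

Compound 3 `O=[N+]([O-])c1ccc(CN2CCC(n3cc(CC(OCc4cc(-c5cccc(F)c5)no4)c4ccc(Br)cc4)nn3)CC2)cc1` changes the same group again: 3-fluorophenyl in place of 4-cyanophenyl on an aromatic carbon. Among the compounds with values here, no measured step covers this particular exchange; the one step that bears on it, a 1.5-fold lower number from compound 1 to compound 2 (0.18 log units; within the scatter), shows that altering the substituent on this aryl group moved the number little. On that basis a step of no more than the scatter is expected, in either direction.

For compound 3 the value in this assay is estimated at 2500 nM, with a range from 1000 nM to 6000 nM, which corresponds to an expected step of a 1.3-fold higher number from compound 2 to compound 3 (0.10 log units; within the scatter).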

Compound 3, half-maximal inhibitory concentration: 9000 nM
The estimate for compound 3 lay 3.6-fold (0.56 log units) below the measured number; measured number above the stated range.
By their numbers in this assay, from the lowest: compounds 2 and 1 (each within the scatter of the next); then compound 3.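

In this assay the aryl group on this aromatic carbon proves not to be freely exchangeable: 3-fluorophenyl in place of 4-cyanophenyl gives a 4.5-fold higher number from compound 2 to compound 3 (0.65 log units; beyond the scatter) and 3-fluorophenyl in place of 4-methoxyphenyl gives a 3.0-fold higher number from compound 1 to compound 3 (0.48 log units; beyond the scatter) and both steps are modest but beyond the scatter. Going by these compounds alone, compounds 1 and 2, which both carry their substituent at the 4 position of the phenyl, stay within the scatter of each other, while compound 3 is the first of the three to stand apart, on the side of weaker inhibition. Nothing available explains why this exchange moves the number when the earlier one did not.

Compound 3 differs from compounds 1 and 2 both in the substituent and in where it sits on the phenyl, so the compounds shown cannot tell whether the higher number goes with the fluorine or with the 3 position. A 4-fluorophenyl or a 3-cyanophenyl would separate the two, and the compounds shown also leave open how an unsubstituted phenyl or an aminophenyl would compare here.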